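Replacing the aryl group on the amide of compound 1

A few compounds are considered here, and "the series" means these few. Any claim that something is new, unique, unknown or untested is made for them only; others in the source may bear on it.

Of the compounds shown here, two have numbers so far. In a functional assay on A549 cells (Homo sapiens) for cytotoxicity, read by MTT assay, with a stated time of 72 h (a lower number here means a stronger inhibitor, a higher number a weaker inhibitor), compound 1 (`O=C(CN1CCN(c2nnc(Cc3ccncc3)c3ccccc23)CC1)Nc1ccc(Br)cc1`) gives 2710 nM as its reading and compound 2 (`O=C(CN1CCN(c2nnc(Cc3ccccc3)c3ccccc23)CC1)Nc1ccc(F)c(C(F)(F)F)c1`) gives 2480 nM as its reading. These two values lie within the scatter of each other, so compound 1 stands level with compound 2 and the pair cannot be ranked.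

Compound 3 (`O=C(CN1CCN(c2nnc(Cc3ccncc3)c3ccccc23)CC1)Nc1cc(C(F)(F)F)ccc1Cl`) has not yet been measured. It keeps the core of compound 1 and carries 2-chloro-5-(trifluoromethyl)phenyl in place of 4-bromophenyl on an amide-type nitrogen. For the measured compounds named here, no measured step isolates a change of this kind, so the expectation rests on thin ground. Compound 2 also carries a trifluoromethyl group and reads 2480 nM in this assay at a level with compound 1, so no step beyond the scatter is expected. The estimated step is a 1.2-fold lower number from compound 1 to compound 3 (0.09 log units; within the scatter) and it is expected to stay within the scatter. For compound 3 the estimate is 2200 nM in this assay with an expected range from 800 nM to 6000 nM for the measurement.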

Compound 3, half-maximal inhibitory concentration: 1850 nM
Beside the measured number, compound 3's estimate is 1.2-fold (0.08 log units) above it; measured number inside the range.
By their numbers in this assay, from the lowest: compounds 3, 2 and 1 (each within the scatter of the next).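

In this assay, for the compounds shown here, the exchange of 4-bromophenyl for 2-chloro-5-(trifluoromethyl)phenyl on the amide-type nitrogen gives a 1.5-fold lower number from compound 1 to compound 3 (0.17 log units; within the scatter), the first step that isolates this position. On the core of compound 1, the two aryl groups therefore read level, even though they share only the six-membered aromatic ring of carbon and differ in every substituent, so this one pair shows no sensitivity to the change. The bromine leaves and the chlorine and trifluoromethyl enter in a single step, so no share of the reading can be assigned to any one of them, and no evidence on hand explains why the two compounds read level.

Both groups shown are halogen-bearing phenyl rings, so it stays open whether the level reading holds for an unsubstituted phenyl, or for a phenyl carrying an amine or a carboxylic acid. A saturated cyclohexyl or a longer alkyl chain on the same nitrogen would test whether this position needs an aryl group at all.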